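A few compounds are considered here, and "the series" means these few. Any claim that something is new, unique, unknown or untested is made for them only; others in the source may bear on it.

In a functional assay on CCRF-CEM cells (Homo sapiens), read by MTT assay, with a stated time of 72 h (on this read-out lower numbers stand for stronger inhibition and higher numbers for weaker inhibition), compound 1 `COc1nc(N)nc2c1c(-c1ccoc1)cn2[C@@H]1O[C@H](CO)[C@@H](O)[C@H]1O` gives only a limit, > 20000 nM. Compound 2 `Nc1nc(N)c2c(-c3cccs3)cn([C@@H]3O[C@H](CO)[C@@H](O)[C@H]3O)c2n1` likewise gives only a limit in this assay, > 20000 nM, and it thus sits at the limit of > 20000 nM in this assay, at which 2 of the 2 values shown sit. Compound 3 `Nc1nc(N)c2c(-c3ccoc3)cn([C@@H]3O[C@H](CO)[C@@H](O)[C@H]3O)c2n1` has not yet been measured; it differs from compound 2 by furan-3-yl in place of thiophen-2-yl on an aromatic carbon. Among the measured compounds shown here, both measured values are limits and show no step between the two compounds. In this assay the step that the limit leaves unreadable from compound 2 to compound 3 is expected to be none beyond the scatter. Compound 3 is therefore estimated at 30000 nM, within a range from 15000 nM to 100000 nM, most likely reported again only as a limit.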

Compound 3, half-maximal inhibitory concentration: > 20000 nM
Compound 3: a limit, no number (the forecaster's own chance of this, stated with the estimate: 85%); the middle value does not contradict the limit.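

Compound 3 gives only a limit, so its steps from compound 2 and from compound 1 cannot be read: the limit of > 20000 nM in this assay, at which 3 of the 3 values shown sit. The compounds shown leave open whether either exchange, furan-3-yl for thiophen-2-yl or amino for methoxy, changes anything in this assay.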